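This account rests on a few compounds, and the source may have more. Where it says the series, first, only, none or still open, it means among the compounds named here.

In an ADME assay on WI-38 cells (Homo sapiens) for cytotoxicity, read by MTT assay, with a stated time of 72 h (a lower number here means a stronger inhibitor, a higher number a weaker inhibitor), compound 1, `CN(C)CCn1cnnc1-c1cc(Oc2ccc(NC(=O)N/N=C/c3ccc(O)c(O)c3)cc2F)ccn1`, gives "not determined" (no result reported), so it cannot be placed on the numbers shown. Two relatives give some footing: in this assay compound 2, `CN(C)CCn1cnnc1-c1cc(Oc2ccc(NC(=O)N/N=C/c3cc(C(C)(C)C)cc(C(C)(C)C)c3O)cc2F)ccn1`, gives 2350 nM, and compound 3, `CN(C)CCn1cnnc1-c1cc(Oc2ccc(NC(=O)N/N=C/c3c[nH]c4ccccc34)cc2F)ccn1`, gives 3620 nM, two values that lie within the usual scatter of each other. Compound 4, `CN(C)CCn1cnnc1-c1cc(Oc2ccc(NC(=O)N/N=C/c3ccc(F)cc3)cc2F)ccn1`, differs from compound 1 in one place: 4-fluorophenyl in place of 3,4-dihydroxyphenyl on a carbon with a double bond to nitrogen. Among the compounds with values here, no measured pair carries this change, so the direction of the step in this assay is unknown, and the expectation is a value in the same region as compounds 2 and 3 rather than a large move either way. Compound 4 is therefore estimated to give 3000 nM in this assay, within a range from 1000 nM to 10000 nM.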

Compound 4, half-maximal inhibitory concentration: 3980 nM
Beside the measured number, compound 4's estimate is 1.3-fold (0.12 log units) below it; the range from low to high includes it.
By their numbers in this assay, from the lowest: compounds 2, 3 and 4 (each within the scatter of the next).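

In this assay there is a 1.1-fold higher number from compound 3 to compound 4 (0.04 log units; within the scatter) with 4-fluorophenyl in place of 1H-indol-3-yl on a carbon with a double bond to nitrogen. This position therefore accepts a monocyclic fluorinated aryl group as well as the bicyclic one without a step beyond the scatter. No measurement offered here explains this result.

Compound 1 has no number, so the step from 3,4-dihydroxyphenyl to 4-fluorophenyl cannot be read. On these data alone, whether an amine or a carboxylic acid on this aromatic ring would move the number beyond the scatter remains open.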